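Isobutyl for isopropyl on the amide of compound 1

The source may report more compounds than this note shows. Statements on the series, on what has been measured and on what is new or still open speak of the compounds shown alone.

Measured in a functional assay on MCF7 cells (Homo sapiens) for antiproliferative activity, read by CCK-8 assay, with a stated time of 72 h; a lower number here means a stronger inhibitor of growth, a higher number a weaker inhibitor of growth:
- compound 1 `CCC1C(=O)N(C)c2cnc(-n3ccc4cc(C(=O)NC(C)C)ccc43)nc2N1c1ccn(C)n1` gives 8420 nM
- compound 2 `CCCNS(=O)(=O)c1ccc(Nc2ncc3c(n2)N(C2CCCC2)[C@H](CC)C(=O)N3C)cc1` gives 344 nM
- compound 3 `CCCCNS(=O)(=O)c1ccc(Nc2ncc3c(n2)N(c2ccn(C)n2)C(CC)C(=O)N3C)cc1` gives 5780 nM

Compound 1 (8420 nM) and compound 3 (5780 nM) lie within the scatter of each other. Compound 2 (344 nM) has a lower number than compound 1, beyond the scatter. Compound 4 `CCC1C(=O)N(C)c2cnc(-n3ccc4cc(C(=O)NCC(C)C)ccc43)nc2N1c1ccn(C)n1` keeps the core of compound 1 and differs in one place (isobutyl in place of isopropyl on an amide-type nitrogen), with isobutyl in place of isopropyl on an amide-type nitrogen. Among the compounds with values here, no measured pair shows this change, so no step beyond the scatter is expected in this assay. The estimated step is small (a 1.1-fold lower number from compound 1 to compound 4 (0.02 log units; within the scatter)). The estimate for compound 4 is 8000 nM, with an expected range from 3500 nM to 18000 nM.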

Compound 4, concentration for 50% growth inhibition: 4810 nM
The estimate for compound 4 lay 1.7-fold (0.22 log units) above the measured number; low and high end bracket the measured number.
By their numbers in this assay, from the lowest: compound 2; then compounds 4, 3 and 1 (each within the scatter of the next).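

In this assay, within the data shown here, the step of a 1.8-fold lower number from compound 1 to compound 4 (0.24 log units; within the scatter) is the only matched step and shows that isobutyl can stand in place of isopropyl on this amide-type nitrogen without a change beyond the scatter. Compound 4 therefore stays with compound 1 in the same range, still apart from nothing that this single pair could resolve. No measured evidence bears on this result.

From the compounds shown here alone, whether a longer chain, a cyclopropyl group or a chain carrying an amine on this nitrogen would give a step beyond the scatter remains open. So does the effect of a carboxylic acid in place of the amide.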